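The compounds below may be only part of what the source reports. "The series", "measured", "known", "first", "only" and "open" are said of these compounds alone.

Measured so far:
Compound 1, `COc1ccccc1-c1nnc(-c2ccc(C(=O)N/N=C/c3ccc([N+](=O)[O-])cc3)cc2)o1`: 203000 nM
Compound 2, `COc1ccccc1-c1nnc(-c2ccc(C(=O)N/N=C/c3ccccc3[N+](=O)[O-])cc2)o1`: 161000 nM
Compound 3, `COc1ccccc1-c1nnc(-c2ccc(C(=O)N/N=C/c3ccc(O)c(O)c3)cc2)o1`: 100000 nM

All three share one core and differ only in the ring attached to the carbon with a double bond to nitrogen. In an ADME assay on THP-1 cells (Homo sapiens) for cytotoxicity (a lower number here means a stronger inhibitor, a higher number a weaker inhibitor), compound 2 gives 161000 nM, a number that sits between those of compound 1 and compound 3. The step of a 1.3-fold lower number from compound 1 to compound 2 (0.10 log units; within the scatter) and the step of a 1.6-fold lower number from compound 2 to compound 3 (0.21 log units; within the scatter) are both within the scatter, so on these numbers compound 2 is not separated from either neighbour.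

Compound 4, `COc1ccccc1-c1nnc(-c2ccc(C(=O)N/N=C/c3ccccc3O)cc2)o1`, is made from compound 2 by one change: hydroxy in place of nitro on an aromatic carbon. Within the data shown here, two measured steps bear on it. Moving the nitro group on that ring, a 1.3-fold lower number from compound 1 to compound 2 (0.10 log units; within the scatter), did almost nothing, and trading a nitro group for hydroxy groups, a 1.6-fold lower number from compound 2 to compound 3 (0.21 log units; within the scatter), stayed within the scatter; only a 2.0-fold lower number from compound 1 to compound 3 (0.31 log units; beyond the scatter) was a modest change. The expectation for this assay is therefore a small step, if any, toward a lower number, expressed as a 1.2-fold lower number from compound 2 to compound 4 (0.09 log units; within the scatter). Compound 4 is estimated at 130000 nM, with a range from 60000 nM to 280000 nM.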

Compound 4, half-maximal inhibitory concentration: 207000 nM
Compound 4: middle estimate off by 1.6-fold (0.20 log units), on the low side; low and high end bracket the measured number.
By their numbers in this assay, from the lowest: compounds 3, 2, 1 and 4 (each within the scatter of the next, the first and the last beyond it).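

In this assay, hydroxy in place of nitro on this aromatic carbon, ortho to a large group, gives a 1.3-fold higher number from compound 2 to compound 4 (0.11 log units; within the scatter), so the two groups cannot be told apart at this place, even though they differ in size and in hydrogen-bond donors. The 2-hydroxyphenyl ring also cannot be told apart from the 4-nitrophenyl ring, with a 1.0-fold higher number from compound 1 to compound 4 (0.01 log units; within the scatter), so carrying a hydroxy group does not by itself separate a compound from the nitro compounds. The new compound does show a modest difference between the two hydroxy-bearing rings, with a 2.1-fold higher number from compound 3 to compound 4 (0.32 log units; beyond the scatter) when 2-hydroxyphenyl replaces 3,4-dihydroxyphenyl, but nothing available gives a reason for this difference.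

The compounds shown leave open whether either hydroxy group of the 3,4-dihydroxyphenyl ring alone would match the number of compound 3, or whether both are needed. They also leave open whether an amine or a carboxylic acid on this ring would stay within the scatter of the nitro and hydroxy compounds or move the number clearly away from them.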